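This account rests on a few compounds, and the source may have more. Where it says the series, first, only, none or still open, it means among the compounds named here.

Compounds measured so far:
Compound 1 `Cc1ccc(C(C)C)c(OCCCCCCN2C[C@H](O)[C@@H](O)[C@H](O)[C@H]2CO)c1`: 62000 nM
Compound 2 `OC[C@@H]1[C@@H](O)[C@H](O)[C@@H](O)CN1CC/C=C/CCOc1cc(F)ccc1F`: > 500000 nM
Compound 3 `OC[C@@H]1[C@@H](O)[C@H](O)[C@@H](O)CN1CCCCCCOc1ccccc1C(F)(F)F`: > 500000 nM

These three compounds were tested in an ADME assay on MDBK cells (Bos taurus) for cytotoxicity, read by MTT assay; a lower number here means that less compound is tolerated, a higher number that more compound is tolerated. Among the compounds with values here, compound 1 gives 62000 nM, and it is the only compound here with an actual number. Compound 2 reads > 500000 nM, which is a limit of the assay and not a number. Compound 3 reads > 500000 nM, which is also a limit. Compound 1 therefore has no measured number to be ranked against.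

The next compound is compound 4 `Cc1ccc(C(C)(C)C)c(OCCCCCCN2C[C@H](O)[C@@H](O)[C@H](O)[C@H]2CO)c1`, which keeps the core and the chain of compound 1 and changes one group: methyl in place of hydrogen on a saturated chain carbon bound to an aromatic carbon and two saturated chain carbons. Read one bond further out, this is isopropyl to tert-butyl. Within the data shown here, no measured pair of compounds shows what such a change does in this assay, so the best starting point is compound 1 at 62000 nM. No shift beyond the usual scatter is expected, and the estimated change is a 1.2-fold lower number from compound 1 to compound 4 (0.09 log units; within the scatter). For compound 4 the expected value is 50000 nM, with an estimated range from 20000 nM to 125000 nM.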

Compound 4, half-maximal cytotoxic concentration: 85000 nM
For compound 4 the middle estimate is 1.7-fold (0.23 log units) below the measured one; measured number inside the range.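

The change from isopropyl to tert-butyl in this assay gives a 1.4-fold higher number from compound 1 to compound 4 (0.14 log units; within the scatter). Within the data shown here, this is the first pair of compounds here that differ in one place and both carry a real number, so it gives a first direct reading of this position. On a saturated chain carbon bound to an aromatic carbon and two saturated chain carbons, methyl in place of hydrogen produces no shift that can be told apart from repeat scatter, though a single pair sets no pattern.

As far as these compounds go, whether an amine or a carboxylic acid at this place would move the number remains open, as does the effect of a longer chain between the core and the oxygen. The other two compounds give no help with these questions, as each differs from these in more than one place and their values are limits: the limit of > 500000 nM in this assay, at which 2 of the 4 values shown sit.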